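Pyridyl for aminophenyl on the triazole of compound 2

This account rests on a few compounds, and the source may have more. Where it says the series, first, only, none or still open, it means among the compounds named here.

For the measured compounds named here, compound 2 `Nc1ccc(-c2cn(Cc3cc(C(=O)O)cc(-c4ccccc4C(=O)O)c3)nn2)cc1` gives 80500 nM in an assay on cells for inhibition of ubiquitin carboxyl-terminal hydrolase isozyme L5 (Homo sapiens), read by fluorescence, with a stated time of 30 min (a lower number here means a stronger inhibitor, a higher number a weaker inhibitor), the lowest of the three numbers so far. Compound 1 `Nc1ccc(-c2cn(Cc3cc(C(=O)O)cc(-c4ccc(C(=O)O)cc4)c3)nn2)cc1` gives 285000 nM in this assay, and the step of a 3.5-fold lower number from compound 1 to compound 2 (0.55 log units; beyond the scatter) shows the 2-carboxyphenyl arm is the better of the two. Compound 3 `O=C(O)c1cc(Cn2cc(-c3ccc(NCc4ccccc4)cc3)nn2)cc(-c2ccccc2C(=O)O)c1` gives 215000 nM in this assay; the step of a 2.7-fold higher number from compound 2 to compound 3 (0.43 log units; beyond the scatter) shows that adding to the amine nitrogen costs a modest amount.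

Compound 4 `O=C(O)c1cc(Cn2cc(-c3cccnc3)nn2)cc(-c2ccccc2C(=O)O)c1` is not yet measured. It differs from compound 2 by pyridin-3-yl in place of 4-aminophenyl on an aromatic carbon. Going by the values given here, no measured step removes the 4-aminophenyl outright, so only the step from compound 2 to compound 3 bears on it, and then indirectly: it shows the amine end of the molecule is not indifferent to change. A step of similar modest size, toward a higher number, is therefore expected, with wide uncertainty. For compound 4 the expected step is a 1.9-fold higher number from compound 2 to compound 4 (0.27 log units; within the scatter), and the estimate is 150000 nM, within a range of 50000 nM to 450000 nM.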

Compound 4, half-maximal inhibitory concentration: 252000 nM
Compound 4: middle estimate off by 1.7-fold (0.23 log units), on the low side; the measured number falls inside the stated range.
By their numbers in this assay, from the lowest: compound 2; then compounds 3, 4 and 1 (each within the scatter of the next).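

In this assay, for the compounds shown here, the change gives a 3.1-fold higher number from compound 2 to compound 4 (0.50 log units; beyond the scatter), and this is the first measured change that replaces the whole 4-aminophenyl on the five-membered aromatic ring rather than adding to its amine nitrogen. Compound 2 therefore holds its place as the lowest number against a change of the whole group as well as against benzyl on the amine, so this position does not accept every aromatic ring equally. The exchange alters the ring, the hydrogen-bond donor and the heavy-atom count together, and no measurement here bears on why the number rises.

The shown compounds do not separate the loss of the amine from the arrival of the ring nitrogen. A plain phenyl, 3-aminophenyl or pyridin-4-yl at this position would bear directly on that question.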